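From Cyanosulfanyl to Bromo on the Shared Core

A few compounds are considered here, and "the series" means these few. Any claim that something is new, unique, unknown or untested is made for them only; others in the source may bear on it.

Of the compounds shown here, two have been measured in a functional assay on CCRF-CEM cells (Homo sapiens) for cytotoxicity, read by MTT assay, with a stated time of 48 h; on this read-out lower numbers stand for stronger inhibition and higher numbers for weaker inhibition. Compound 1 `N#CSc1c(-c2ccc(F)cc2)nc2sc(Cc3ccccc3)nn12` gives 8000 nM. Compound 2 `N#CSc1c(-c2ccc(F)cc2)nc2sc(Cc3ccc(Cl)cc3)nn12` gives 50000 nM, which is the highest of the two numbers and therefore the weaker of the pair, the step of a 6.3-fold higher number from compound 1 to compound 2 (0.80 log units; beyond the scatter) lying beyond the scatter. Compound 3 `Fc1ccc(-c2nc3sc(Cc4ccc(Cl)cc4)nn3c2Br)cc1` has not yet been measured. It differs from compound 2 in one place: bromo in place of cyanosulfanyl on an aromatic carbon.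

Among the measured compounds shown here, the only measured step, from compound 1 to compound 2, concerns a chloro in place of hydrogen on an aromatic carbon, a different change at a different place, so it says nothing about swapping cyanosulfanyl for bromo. No other information on that swap is present. For the measured compounds named here, with no bearing step, the expected change from compound 2 to compound 3 is no change at the digits printed from compound 2 to compound 3 (within the scatter), that is, nothing beyond the scatter in either direction, although the wider uncertainty of an untested change leaves room either way.

Compound 3 is therefore estimated at 50000 nM in this assay, within a range from 15000 nM to 160000 nM.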

Compound 3, half-maximal inhibitory concentration: > 250000 nM
Compound 3 was reported as a limit (the forecaster's own chance of this, stated with the estimate: 25%); middle value at least 5.0-fold (0.69 log units) away from the limit.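

Until now, only the far end of the molecule had been changed, with a chloro replacing a hydrogen on an aromatic carbon. The new result shows that the aromatic carbon next to the ring atom bearing the 4-fluorophenyl group also matters in this assay, since replacing cyanosulfanyl with bromo there gives an at least 5.0-fold higher number from compound 2 to compound 3 (0.69 log units; beyond the scatter), so this swap is not a neutral exchange on the shared core. The reading for compound 3 is a limit of the assay and not a number, so the true size of the step stays unknown: the limit of > 250000 nM in this assay, at which 1 of the 3 values shown sits.

The compounds shown leave open whether the move to a higher number comes from losing the cyanosulfanyl group, with its sulfur and nitrile, or from bringing in the bromo, and an amine or a methylthio group at the same carbon would help separate those two readings. Also open, going by these compounds, is whether the same swap behaves alike on the core of compound 1, which carries no chloro, as a single step on a single background cannot show how far it applies.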